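The source may hold more compounds than are shown below. What is called first, only, known or untested is meant among the compounds shown, and "the series" means these compounds.

Working notes on the sulfonamide-piperidine series.

Of the compounds shown here, two have numbers so far in a functional assay on DLD-1 cells (Homo sapiens) for antiproliferative activity, read by CellTiter-Glo, with a stated time of 72 h; a higher number here means a weaker inhibitor, a lower number a stronger inhibitor. Compound 1 `Cc1ccc(-c2ccccc2S(=O)(=O)N2CCC(N3CCC(C)CC3)CC2)cc1` gives 366 nM in this assay. Compound 2 `CC1CCN(C2CCN(S(=O)(=O)c3cccc(N)c3)CC2)CC1` gives 3400 nM in this assay. Within the data shown here, compound 1 thus holds the lower of the two numbers, and the gap to compound 2 lies beyond the scatter of repeated measurements; the two structures differ in more than one place, so no single step between them is counted.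

The next compound, compound 3 `CC1CCN(C2CCN(S(=O)(=O)c3ccccc3-c3ccccc3)CC2)CC1`, differs from compound 1 in one place: hydrogen in place of methyl on an aromatic carbon, para to a large group, which reads as 4-methylphenyl to phenyl one bond further out. Among the measured compounds shown here, no measured pair isolates this change, so the expected size of the step rests on the single methyl lost. A small move towards a higher number, or none beyond the scatter, is expected. On that basis compound 3 is estimated at 600 nM in this assay, within a range of 250 nM to 1500 nM. The step this estimate means, a 1.6-fold higher number from compound 1 to compound 3 (0.21 log units; within the scatter), is expected to stay close to the scatter.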

Compound 3, half-maximal inhibitory concentration: 0.96 nM
Beside the measured number, compound 3's estimate is 630-fold (2.80 log units) above it; the measured number lies below the stated range.
By their numbers in this assay, from the lowest: compound 3; then compound 1; then compound 2.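

Hydrogen in place of methyl on an aromatic carbon, para to a large group, gives a 380-fold lower number from compound 1 to compound 3 (2.58 log units; beyond the scatter) in this assay, so this one position on the 4-methylphenyl of compound 1 is highly sensitive to a single carbon. Among these compounds, compound 1 and compound 2 differ in more than one place and could not show this; the change from 4-methylphenyl to phenyl is the first single change with a measured step, and it lies far beyond the scatter. Nothing at hand gives a reason for a step of this size.

This single pair leaves open whether the step belongs to the methyl itself or to any group at this place: fluorine, methoxy or an amine on the same aromatic carbon would show whether the numbers stay near that of compound 3 or move towards that of compound 1. It also leaves open whether a methyl elsewhere on this ring, or the same change on the aminophenyl sulfonamide of compound 2, would give a step of similar size.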